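A para-methoxy on the benzoyl ring of compound 3

The source may report more compounds than this note shows. Statements on the series, on what has been measured and on what is new or still open speak of the compounds shown alone.

Three compounds share one core, a substituted amide attached to an aromatic ring that carries an unsaturated ketone. Compound 3 `Cc1nc(C)c(/C=C/C(=O)c2ccc(NC(=O)c3ccccc3)cc2)nc1C` carries a plain benzoyl group; in a functional assay on MDA-MB-231 cells (Homo sapiens) for antiproliferative activity, read by CCK-8 assay, with a stated time of 72 h (on this read-out higher numbers stand for weaker inhibition and lower numbers for stronger inhibition), compound 3 gives 1840 nM. Compound 1 `Cc1nc(C)c(/C=C/C(=O)c2ccc(NC(=O)c3ccccc3F)cc2)nc1C` has a fluoro on that benzoyl ring, and in this assay compound 1 gives 1980 nM, so that a 1.1-fold lower number from compound 1 to compound 3 (0.03 log units; within the scatter). Compound 2 `COc1cccc(OC)c1C(=O)Nc1ccc(C(=O)/C=C/c2nc(C)c(C)nc2C)cc1` has two methoxy groups on the benzoyl ring, and compound 2 gives 3850 nM; here a 2.1-fold lower number from compound 2 to compound 3 (0.32 log units; beyond the scatter). Compound 3 thus has the lowest of the three numbers, although compound 1 sits within the scatter of it.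

Compound 4 `COc1ccc(C(=O)Nc2ccc(C(=O)/C=C/c3nc(C)c(C)nc3C)cc2)cc1` differs from compound 3 by a single change: methoxy in place of hydrogen on an aromatic carbon. The two measured steps that touch the benzoyl ring point the same way: a fluoro made no difference beyond the scatter, and two methoxy groups raised the number modestly. A single methoxy at a different place is therefore expected to leave the number unchanged or to raise it slightly, so that a 1.3-fold higher number from compound 3 to compound 4 (0.12 log units; within the scatter) is expected. Compound 4 is accordingly estimated at 2400 nM, with a range from 1200 nM to 4800 nM.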

Compound 4, half-maximal inhibitory concentration: 1600 nM
Compound 4: the middle estimate sits 1.5-fold (0.18 log units) above what was measured; the measured number falls inside the stated range.
By their numbers in this assay, from the lowest: compounds 4, 3, 1 and 2 (each within the scatter of the next, the first and the last beyond it).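

On the benzoyl ring, at the carbon para to a large group, methoxy in place of hydrogen shifts the number only within the scatter in this assay: a 1.2-fold lower number from compound 3 to compound 4 (0.06 log units; within the scatter), and likewise a 1.2-fold lower number from compound 1 to compound 4 (0.09 log units; within the scatter). Phenyl, 2-fluorophenyl and 4-methoxyphenyl on the carbonyl carbon therefore cannot be told apart on this read-out. Among the compounds shown here, a methoxy on this ring also does not by itself go with the higher number of compound 2, since a 2.4-fold lower number from compound 2 to compound 4 (0.38 log units; beyond the scatter), a modest step of about the same size as the one from compound 2 to compound 3. Nothing shown here offers an explanation for any of these steps.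

The compounds shown leave open whether the higher number of compound 2 follows from having two methoxy groups or from where those groups sit on the ring. They also leave open whether a different group at this same place, such as an amine, a carboxylic acid or a longer chain like butoxy, would stay within the scatter of compound 3.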